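Compound 3 to compound 4: ethoxycarbonyl for phenyl

The source may report more compounds than this note shows. Statements on the series, on what has been measured and on what is new or still open speak of the compounds shown alone.

Measured so far:
- compound 1 `COc1cc(/C=C/C(=O)c2cccc(N)c2)ccc1O`: 2.87 ug/mL
- compound 2 `COC(=O)C(=O)Nc1cccc(C(=O)/C=C/c2ccc(O)c(OC)c2)c1`: 1.5 ug/mL
- compound 3 `COc1cc(/C=C/C(=O)c2cccc(NC(=O)c3ccccc3)c2)ccc1O`: 0.37 ug/mL

In a functional assay on HUVEC cells (Homo sapiens) for inhibition (a lower number here means a stronger inhibitor, a higher number a weaker inhibitor), compound 3 has the lowest number of the three, 0.37 ug/mL, and is the strongest inhibitor so far. Its steps to both other compounds lie beyond the scatter.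

The next compound is compound 4 `CCOC(=O)C(=O)Nc1cccc(C(=O)/C=C/c2ccc(O)c(OC)c2)c1`, with ethoxycarbonyl in place of phenyl on a carbonyl carbon.

Among the measured compounds shown here, two measured steps bear on this. The most direct is a 4.1-fold lower number from compound 2 to compound 3 (0.61 log units; beyond the scatter), where phenyl took the place of methoxycarbonyl on the same carbonyl carbon. The change to compound 4 runs the other way, so that step should largely reverse. The series also shows a 1.9-fold lower number from compound 1 to compound 2 (0.28 log units; within the scatter) for (methoxycarbonyl)carbonyl on the nitrogen, against a 7.8-fold lower number from compound 1 to compound 3 (0.89 log units; beyond the scatter) for benzoyl. For the measured compounds named here, no measured compound carries ethoxycarbonyl, so its difference from methoxycarbonyl is unknown, and the range is kept wide.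

A modest rise in this assay is therefore expected, estimated as a 4.1-fold higher number from compound 3 to compound 4 (0.61 log units; beyond the scatter). The estimate for compound 4 is 1.5 ug/mL, with an expected range of 0.7 ug/mL to 3.2 ug/mL.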

Compound 4, half-maximal inhibitory concentration: 13.3 ug/mL
Beside the measured number, compound 4's estimate is 8.9-fold (0.95 log units) below it; measured number above the stated range.
By their numbers in this assay, from the lowest: compound 3; then compounds 2 and 1 (each within the scatter of the next); then compound 4.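

Ethoxycarbonyl in place of phenyl on the carbonyl carbon gives a 36-fold higher number from compound 3 to compound 4 (1.56 log units; beyond the scatter) in this assay, a much larger change at this position than the earlier compounds had shown. The ester end of the group is itself sensitive, as methyl in place of hydrogen on the saturated chain carbon bound to the oxygen gives an 8.9-fold higher number from compound 2 to compound 4 (0.95 log units; beyond the scatter), so methoxycarbonyl and ethoxycarbonyl cannot be treated as interchangeable here. Placing (ethoxycarbonyl)carbonyl on the nitrogen gives a 4.6-fold higher number from compound 1 to compound 4 (0.67 log units; beyond the scatter), which makes compound 4 the exception among these compounds: benzoyl on that nitrogen in compound 3 lowers the number beyond the scatter, and (methoxycarbonyl)carbonyl in compound 2 stays within it.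

Still open, going by these compounds, is whether the number keeps rising with a longer chain such as propoxycarbonyl, and how a carboxylic acid or an amide in place of the ester would read in this assay. No measurement at hand offers an explanation for the size of these steps.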